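The source may report more compounds than this note shows. Statements on the series, on what has been measured and on what is new or still open speak of the compounds shown alone.

Compound 1: `O=C(N[C@H]1CN(S(=O)(=O)c2ccccc2)C[C@@H]1C(=O)N[C@H]1CCCNC1)c1cc(-c2ccccc2Cl)on1`, 98%
Compound 2: `O=C(N[C@H]1CN(S(=O)(=O)c2ccccc2)C[C@@H]1C(=O)NC[C@@H]1CCCN1)c1cc(-c2ccccc2Cl)on1`, 102%
Compound 3: `O=CN1CCC[C@H](NC(=O)[C@H]2CN(S(=O)(=O)c3ccccc3)C[C@@H]2NC(=O)c2cc(-c3ccccc3Cl)on2)C1`, 90%

All three were tested in a functional assay on HEK293 cells for agonist activity at growth hormone secretagogue receptor type 1 (Homo sapiens), read by HTRF and inositol phosphate accumulation, with a stated time of 90 min, in the presence of a further agent that is not named here; a higher number here means a larger maximal response, a lower number a smaller maximal response. Compound 3 sits at the bottom of the three numbers, though only just: its nearest neighbour is compound 1, and the step of a number 8 percentage points lower from compound 1 to compound 3 (within the scatter) is within the scatter, while the step of a number 12 percentage points lower from compound 2 to compound 3 (beyond the scatter) is the only one that reaches beyond it, and even that one is modest. The three compounds share one core and differ only in the amine-bearing ring attached to the amide-type nitrogen and in what sits on that ring's nitrogen.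

Compound 4, `CC(=O)N1CCC[C@H](NC(=O)[C@H]2CN(S(=O)(=O)c3ccccc3)C[C@@H]2NC(=O)c2cc(-c3ccccc3Cl)on2)C1`, is the next step from compound 3. The change is methyl in place of hydrogen on a carbonyl carbon. Of the measured steps, the closest in kind is a number 8 percentage points lower from compound 1 to compound 3 (within the scatter), where the same ring nitrogen went from hydrogen to formyl without a move beyond the scatter. Among the measured compounds shown here, no measured step alters the group on the carbonyl carbon itself, so the evidence is indirect. On this basis the step of a number 2 percentage points higher from compound 3 to compound 4 (within the scatter) is expected to stay within the scatter. Compound 4 is therefore estimated at 92%, with a range from 80% to 104%.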

Compound 4, largest response reached (Emax), in percent of the reference or control that the assay uses in the growth hormone secretagogue receptor type 1 assay: 91%
Beside the measured number, compound 4's estimate is 1 percentage points above it; the range from low to high includes it.
By their numbers in the growth hormone secretagogue receptor type 1 assay, from the lowest: compounds 3, 4, 1 and 2 (each within the scatter of the next, the first and the last beyond it).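

Among the compounds shown here, in the growth hormone secretagogue receptor type 1 assay, this is the first measured change on the carbonyl carbon itself, and going from formyl to acetyl leaves the maximal response unmoved within the scatter, a number 1 percentage points higher from compound 3 to compound 4 (within the scatter), just as acetyl in place of hydrogen on the ring nitrogen does, a number 7 percentage points lower from compound 1 to compound 4 (within the scatter), while the larger replacement of the whole group on the amide-type nitrogen gives a number 11 percentage points lower from compound 2 to compound 4 (beyond the scatter). In a physicochemical assay for solubility, at pH 7.4 (on this read-out lower numbers stand for lower solubility and higher numbers for higher solubility), compound 3 gives 4500 nM, which adds a second read-out for this position. In the physicochemical assay, compound 4 gives < 500 nM, which is a limit of the assay and not a number, so the step of an at least 9.0-fold lower number from compound 3 to compound 4 (0.95 log units; beyond the scatter) fixes only a minimum size, and the methyl on the carbonyl carbon separates the two read-outs by shifting solubility while the maximal response holds: the limit of < 500 nM in the physicochemical assay, at which 1 of the 2 values shown sits.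

As far as these compounds go, whether a longer chain on this carbonyl carbon, such as the propionyl group, or an amine or a carboxylic acid carried there, would also hold the maximal response remains open. From the compounds shown here alone, how far the solubility of compound 4 actually lies under its limit also remains open.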